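Acetyl on the aromatic nitrogen: compound 3 to compound 4

The source may hold more compounds than are shown below. What is called first, only, known or untested is meant among the compounds shown, and "the series" means these compounds.

Of the compounds shown here, three have been measured in a functional assay on DU-145 cells (Homo sapiens) for cytotoxicity, read by MTT assay, with a stated time of 72 h; on this read-out lower numbers stand for stronger inhibition and higher numbers for weaker inhibition. Compound 1 `COc1cc(OC)cc(/C(=C\c2cn(C(C)=O)c3ccc(OCc4ccccc4)cc23)C(=O)O)c1` gives 880 nM, compound 2 `CC(=O)n1cc(/C=C(/C(=O)O)c2ccc(Cl)cc2)c2cc(OCc3ccccc3)ccc21` gives 1130 nM, and compound 3 `O=C(O)/C(=C/c1c[nH]c2ccc(OCc3ccccc3)cc12)c1ccccc1` gives 34700 nM, the highest of the three numbers; its nearest neighbour is compound 2, which sits far beyond the scatter from it, and compound 1 lies still further.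

Compound 4 `CC(=O)n1cc(/C=C(/C(=O)O)c2ccccc2)c2cc(OCc3ccccc3)ccc21` differs from compound 3 in one place: acetyl in place of hydrogen on an aromatic nitrogen. Within the data shown here, no measured pair shows this change on its own, so no direct step is available. Among the measured compounds shown here, the only measured step, a 1.3-fold higher number from compound 1 to compound 2 (0.11 log units; within the scatter), concerns a different position and merely shows that, with the acetyl present, exchanging the aryl group on the chain carbon costs nothing beyond the scatter. For the measured compounds named here, what compounds 1 and 2 do show is that both acetyl-bearing members give the lower numbers of the three, while the single member without acetyl, compound 3, gives a number that lies beyond the scatter from either of them.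

Taking compounds 1 and 2 as the guide, compound 4 is expected to land well below compound 3, with the step of a 14-fold lower number from compound 3 to compound 4 (1.14 log units; beyond the scatter) estimated as a large fall. The estimate for compound 4 in this assay is 2500 nM, in the range 700 nM to 12000 nM.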

Compound 4, half-maximal inhibitory concentration: 26700 nM
For compound 4 the middle estimate is 11-fold (1.03 log units) below the measured one; the whole stated range lies below it.
By their numbers in this assay, from the lowest: compounds 1 and 2 (each within the scatter of the next); then compounds 4 and 3 (each within the scatter of the next).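

In this assay, acetyl in place of hydrogen on an aromatic nitrogen gives a 1.3-fold lower number from compound 3 to compound 4 (0.11 log units; within the scatter) on the phenyl-bearing pair, so in this pair the acetyl alone leaves the number within the scatter and does not by itself bring it into the range of compound 1 and compound 2. With the acetyl held in place, the large steps lie on the aryl group: hydrogen in place of chloro on an aromatic carbon gives a 24-fold higher number from compound 2 to compound 4 (1.37 log units; beyond the scatter) and phenyl in place of 3,5-dimethoxyphenyl gives a 30-fold higher number from compound 1 to compound 4 (1.48 log units; beyond the scatter) in the same assay, so the unsubstituted phenyl separates from both substituted aryl groups. No supporting measurement bears on these steps, and their origin remains unassigned.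

Open, going by these compounds, is whether acetyl in place of hydrogen on the aromatic nitrogen gives a step of the same size when the aryl group is 4-chlorophenyl or 3,5-dimethoxyphenyl rather than phenyl. Also open, on these data alone, is whether a fluoro or an amine on the aromatic carbon that bears chloro in compound 2, or a propanoyl group in place of acetyl on the aromatic nitrogen, would fit the same picture.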